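The compounds below may be only part of what the source reports. "The series", "measured", "known", "first", "only" and "open" are said of these compounds alone.

Working notes on the series.

Of the compounds shown here, three have been measured in a functional assay on A549 cells (Homo sapiens) for inhibition, read by MTT assay, with a stated time of 72 h; on this read-out lower numbers stand for stronger inhibition and higher numbers for weaker inhibition. Compound 1 `CN(C(=O)NC(=O)c1ccc(Cl)c(Cl)c1)c1nc(C(F)(F)F)c(C(=O)N/N=C/c2ccc([N+](=O)[O-])cc2)s1` gives 6.44 ug/mL. Compound 2 `CN(C(=O)NC(=O)c1ccccc1)c1nc(C(F)(F)F)c(C(=O)N/N=C/c2cccc([N+](=O)[O-])c2)s1` gives 20.7 ug/mL. Compound 3 `Cc1nc(N(C)C(=O)NC(=O)c2ccc(Cl)cc2Cl)sc1C(=O)N/N=C/c1ccc(C(F)(F)F)cc1` gives 30.2 ug/mL. On these numbers compound 2 stands second highest of the three; the nearest number is that of compound 3, and the two lie within the usual scatter of this kind of measurement, so no order between them is claimed. The furthest number is that of compound 1, which lies beyond the scatter on the lower side.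

Compound 4 `CN(C(=O)NC(=O)c1ccc(Cl)c(Cl)c1)c1nc(C(F)(F)F)c(C(=O)N/N=C/c2cccc([N+](=O)[O-])c2)s1` has not been measured. It differs from compound 2 in one place: 3,4-dichlorophenyl in place of phenyl on a carbonyl carbon. Compound 1 also carries a 3,4-dichlorophenyl group on this carbonyl carbon, and compound 1 returns the lowest number of the three, whereas compound 2, with the plain phenyl group, returns a clearly higher one. For the measured compounds named here, no directly comparable pair of measured compounds separates this change from others in the set, so its size cannot be read off. The step from compound 2 to compound 4 is nevertheless expected to be a 2.1-fold lower number from compound 2 to compound 4 (0.32 log units; beyond the scatter), a decrease of moderate size beyond the scatter, in the direction of compound 1. Compound 4 is expected to give 10 ug/mL, with a likely range from 4 ug/mL to 25 ug/mL.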

Compound 4, half-maximal inhibitory concentration: 6.34 ug/mL
Estimate against measurement, compound 4: 1.6-fold (0.20 log units) above; low and high end bracket the measured number.
By their numbers in this assay, from the lowest: compounds 4 and 1 (each within the scatter of the next); then compounds 2 and 3 (each within the scatter of the next).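

In this assay, for the compounds shown here, the step of a 3.3-fold lower number from compound 2 to compound 4 (0.51 log units; beyond the scatter) gives the first direct reading of 3,4-dichlorophenyl in place of phenyl on a carbonyl carbon, with the rest of the structure unchanged; the earlier compounds could not separate this change from the others in the set. With 3,4-dichlorophenyl held on that carbonyl carbon, the step of a 1.0-fold lower number from compound 1 to compound 4 (0.01 log units; within the scatter) shows that 3-nitrophenyl in place of 4-nitrophenyl on a carbon with a double bond to nitrogen stays within the scatter, so this change has no readable effect in this one pair. No measurement available here bears on the reason for either result.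

From the compounds shown here alone, the two steps rest on single pairs, so it remains open whether the gain from 3,4-dichlorophenyl would carry over to compounds with 4-nitrophenyl or with the 4-(trifluoromethyl)phenyl group of compound 3, whose differences from the other compounds cannot be read as single changes. Going by these compounds, it is also open how a single chlorine, a methoxy group or a carboxylic acid on the phenyl ring at this carbonyl carbon would compare with 3,4-dichlorophenyl.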